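The compounds below may be only part of what the source reports. "The series", "measured", "known", "first", "only" and "open" are said of these compounds alone.

Measured compounds:
Compound 1, `CN1C(=O)C2(C(C#N)=C(N)Oc3cc4oc(-c5ccccc5)cc(=O)c4c(O)c32)c2ccccc21`, gives in a functional assay on NCI-H1299 cells (Homo sapiens) for antiproliferative activity, read by MTT assay, with a stated time of 48 h (on this read-out lower numbers stand for stronger inhibition and higher numbers for weaker inhibition), the value > 50000 nM, a limit of the assay rather than a number.
Compound 2, `CN1C(=O)C2(C(C#N)=C(N)Oc3cc4oc(-c5ccccc5)cc(=O)c4c(O)c32)c2cccc(Cl)c21`, gives in this assay the value > 50000 nM, also a limit.
Compound 3, `CN1C(=O)C2(C(C#N)=C(N)Oc3cc4oc(-c5ccccc5)cc(=O)c4c(O)c32)c2cc(Br)ccc21`, gives in this assay the value 7610 nM.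

Compound 1 therefore stands at the limit of > 50000 nM in this assay, at which 2 of the 3 values shown sit. Compound 4, `N#CC1=C(N)Oc2cc3oc(-c4ccccc4)cc(=O)c3c(O)c2C12C(=O)Nc1ccccc12`, differs from compound 1 by hydrogen in place of methyl on an amide-type nitrogen in a ring. The two measured steps, a step that the two limits leave unreadable from compound 1 to compound 2 and an at least 6.5-fold lower number from compound 1 to compound 3 (0.81 log units; beyond the scatter), both concern a halogen entering on an aromatic carbon, not the amide-type nitrogen, so neither bears directly on this change. With nothing to point the other way, no shift beyond the scatter is expected in this assay. It is estimated that compound 4 gives 50000 nM, between 20000 nM and 120000 nM, a step of a number no higher from compound 1 to compound 4 (the limit leaves the size open), most probably reported again only as a limit.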

Compound 4, half-maximal inhibitory concentration: > 50000 nM
Compound 4 ended at the assay's limit; the forecaster's own chance of this, stated with the estimate: 65%; the middle value lies on the limit itself.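

No step can be read from compound 1 to compound 4, since both values are limits rather than numbers: the limit of > 50000 nM in this assay, at which 3 of the 4 values shown sit.
The compounds shown leave open whether hydrogen in place of methyl on this amide-type nitrogen changes activity where a measurable value exists, as for compound 3.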